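The source may report more compounds than this note shows. Statements on the series, on what has been measured and on what is new or still open speak of the compounds shown alone.

Compound 1, `CS(=O)(=O)Nc1cccc(-c2nc(C(c3ccc(F)cc3)c3ccc(F)cc3)sc2CC(=O)O)c1`, in an in vitro assay on HEK385-7 cells for displacement of a labelled ligand from prostaglandin D2 receptor 2 (Homo sapiens) (on this read-out higher numbers stand for weaker inhibition and lower numbers for stronger inhibition), gives 40 nM.
Compound 2, `O=C(O)Cc1sc(C(c2ccc(F)cc2)c2ccc(F)cc2)nc1-c1cc(F)nc(F)c1`, in this assay gives 5.4 nM.
Compound 3, `Cc1cc(-c2nc(C(c3ccc(F)cc3)c3ccc(F)cc3)sc2CC(=O)O)ccn1`, in this assay gives 3.1 nM.

Compound 3 has the lowest of these three numbers. Its nearest neighbour is compound 2: the step is a 1.7-fold lower number from compound 2 to compound 3 (0.24 log units; within the scatter), so the two cannot be told apart here. The farthest is compound 1, with a 13-fold lower number from compound 1 to compound 3 (1.11 log units; beyond the scatter). Compound 4, `COc1cc(-c2nc(C(c3ccc(F)cc3)c3ccc(F)cc3)sc2CC(=O)O)ccn1`, differs from compound 3 in one place: methoxy in place of methyl on an aromatic carbon.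

Among the measured compounds shown here, no measured step swaps methyl for methoxy. The steps of a 7.4-fold lower number from compound 1 to compound 2 (0.87 log units; beyond the scatter) and a 13-fold lower number from compound 1 to compound 3 (1.11 log units; beyond the scatter) both replace the whole aromatic group attached to the shared core, so they say little about a small change on a pyridine that stays in place. Closer in kind is a 1.7-fold lower number from compound 2 to compound 3 (0.24 log units; within the scatter), which alters only the substituents on the pyridine ring and stays within the scatter. On that basis compound 4 is expected to sit close to compound 3 in this assay. Compound 4 is therefore expected to show a step of a 1.3-fold higher number from compound 3 to compound 4 (0.11 log units; within the scatter), not beyond the scatter in either direction. The estimate for compound 4 is 4 nM, within a range from 1.5 nM to 12 nM.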

Compound 4, half-maximal inhibitory concentration: 29 nM
Estimate against measurement, compound 4: 7.3-fold (0.86 log units) below, outside the stated range (above it).
By their numbers in this assay, from the lowest: compounds 3 and 2 (each within the scatter of the next); then compounds 4 and 1 (each within the scatter of the next).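

Replacing methyl with methoxy on this aromatic carbon next to the ring nitrogen gives a 9.4-fold higher number from compound 3 to compound 4 (0.97 log units; beyond the scatter) in this assay and shows that this position responds sharply to a small change, whereas the earlier change to the pyridine substituents stayed within the scatter. The same pattern appears against the difluorinated ring, with a 5.4-fold higher number from compound 2 to compound 4 (0.73 log units; beyond the scatter) for 2-methoxypyridin-4-yl in place of 2,6-difluoropyridin-4-yl, so a pyridine at this place does not by itself secure a low number, and a 1.4-fold lower number from compound 1 to compound 4 (0.14 log units; within the scatter) leaves compound 4 indistinguishable from the 3-(methanesulfonamido)phenyl compound despite the whole aromatic group being different. Nothing available here explains why methoxy behaves so differently from methyl on this ring.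

The compounds shown leave open whether the step follows from the added oxygen or from the longer substituent, and an ethyl group or an amine on this same carbon would help separate those two readings. They also leave open whether swapping methyl for methoxy would have a similar effect on any other aromatic group attached to the shared core.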